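Bromo-methyl pyridyl amide from a chlorophenyl triazine thioacetamide

This account rests on a few compounds, and the source may have more. Where it says the series, first, only, none or still open, it means among the compounds named here.

Measured compounds:
compound 1 `O=C(CSc1nncnc1-c1ccccc1Cl)Nc1ccccn1`, 172000 nM
compound 2 `O=C(CSc1nncnc1-c1cccc2ccccc12)N1CCc2ccccc2C1`, 13000 nM
compound 3 `COC(=O)c1ccc(NC(=O)CSc2nncnc2-c2cccc3ccccc23)c(Br)c1`, 173000 nM

In an ADME assay on MT4 cells (Homo sapiens) for cytotoxicity, read by MTT assay (on this read-out higher numbers stand for lower toxicity in this test and lower numbers for higher toxicity in this test), compound 1 gives 172000 nM. This number stands second highest of the three. Within the data shown here, compound 3 gives 173000 nM, a number that sits within the scatter of the one for compound 1, so no order between these two can be read. Compound 2 gives 13000 nM, a number that lies beyond the scatter below compound 1, the only clear separation among the three.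

Compound 4 `Cc1cnc(NC(=O)CSc2nncnc2-c2ccccc2Cl)c(Br)c1` differs from compound 1 in one place: 3-bromo-5-methylpyridin-2-yl in place of pyridin-2-yl on an amide-type nitrogen. Among the measured compounds shown here, the three measured compounds share the core but vary at several positions at once, so no single-point step between them is known, and nothing measured shows what adding bromine and a methyl group to the pyridin-2-yl does here.

The change is expected to move the number for compound 4 little, with a step of a 1.1-fold lower number from compound 1 to compound 4 (0.06 log units; within the scatter) judged as none beyond the scatter. Compound 4 is therefore estimated at 150000 nM, within a range from 50000 nM to 400000 nM.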

Compound 4, half-maximal cytotoxic concentration: 144000 nM
The estimate for compound 4 lay 1.0-fold (0.02 log units) above the measured number, and the stated range covers the measured number.
By their numbers in this assay, from the lowest: compound 2; then compounds 4, 1 and 3 (each within the scatter of the next).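

In this assay, putting 3-bromo-5-methylpyridin-2-yl in place of pyridin-2-yl on an amide-type nitrogen gives a 1.2-fold lower number from compound 1 to compound 4 (0.08 log units; within the scatter), so no change can be read from this swap. Among these compounds, this is the first comparison of compounds that differ in one place only, and it shows that this position accepts the bromine and the methyl group together without a shift in cytotoxicity that stands clear of the scatter. Nothing available explains this result.

Going by these compounds, the bromine and the methyl group entered together, so what either does alone remains open. Also open, on these data alone, is whether a more different group on the amide-type nitrogen, such as a pyridin-2-yl carrying an amine or a carboxylic acid, would move the number beyond the scatter.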